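From compound 3 to compound 4: a far smaller group

The source may hold more compounds than are shown below. What is called first, only, known or untested is meant among the compounds shown, and "the series" means these compounds.

Compound 1 `O=C1O[C@H]([C@@H](O)Cn2cc(-c3ccc(Br)cc3)nn2)C(OCc2ccccc2)=C1OCc1ccccc1`: 5070 nM
Compound 2 `COc1ccccc1-c1cn(C[C@H](O)[C@H]2OC(=O)C(OCc3ccccc3)=C2OCc2ccccc2)nn1`: > 100000 nM, a limit of the assay
Compound 3 `O=C1O[C@H]([C@@H](O)Cn2cc(CNS(=O)(=O)c3ccc(F)cc3)nn2)C(OCc2ccccc2)=C1OCc1ccccc1`: 18300 nM

In a functional assay on HepG2 cells (Homo sapiens) for antiproliferative activity, read by MTT assay, with a stated time of 72 h (on this read-out higher numbers stand for weaker inhibition and lower numbers for stronger inhibition), compound 3 gives 18300 nM, the higher of the two actual numbers, with a 3.6-fold higher number from compound 1 to compound 3 (0.56 log units; beyond the scatter). Compound 4 `O=C1O[C@H]([C@@H](O)Cn2cc(C3CC3)nn2)C(OCc2ccccc2)=C1OCc1ccccc1` remains unmeasured. It carries cyclopropyl in place of (((4-fluorophenyl)sulfonyl)amino)methyl on an aromatic carbon. The measured steps changed that same carbon: an at least 19-fold higher number from compound 1 to compound 2 (1.29 log units; beyond the scatter), an at least 5.4-fold lower number from compound 2 to compound 3 (0.73 log units; beyond the scatter) and the step already given. They range from modest to large and run both ways, so they guide direction only weakly. All three measured groups keep a six-membered aromatic ring, which compound 4 loses. A modest move towards weaker inhibition is expected, as a 2.2-fold higher number from compound 3 to compound 4 (0.34 log units; beyond the scatter). For compound 4 the estimate is 40000 nM, with an expected range of 12000 nM to 100000 nM.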

Compound 4, half-maximal inhibitory concentration: 38100 nM
Compound 4: the middle estimate sits 1.0-fold (0.02 log units) above what was measured; measured number inside the range.
By their numbers in this assay, from the lowest: compound 1; then compound 3; then compound 4. At a limit, above all of these: compound 2.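

In this assay, replacing the sulfonamide-bearing group with cyclopropyl, which has no six-membered aromatic ring and far fewer heavy atoms, gives a 2.1-fold higher number from compound 3 to compound 4 (0.32 log units; beyond the scatter), while the change from 4-bromophenyl gives a 7.5-fold higher number from compound 1 to compound 4 (0.88 log units; beyond the scatter). Against 2-methoxyphenyl, cyclopropyl gives an at least 2.6-fold lower number from compound 2 to compound 4 (0.41 log units; beyond the scatter), a step that rests on a limit of the assay: the limit of > 100000 nM in this assay, at which 1 of the 4 values shown sits. Compounds 1 and 2 both carry an aryl group yet fall on either side of compound 4, so an aryl group alone does not set the order at this carbon.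

As far as these compounds go, how an unsubstituted phenyl, an amine or a longer alkyl chain would behave on this carbon remains open.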